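Chloro for methoxy on an aromatic carbon: compound 4

The source may report more compounds than this note shows. Statements on the series, on what has been measured and on what is new or still open speak of the compounds shown alone.

Compound 3 `COc1ccc(-c2cn(-c3cccc(C(=O)/C=C/c4cc(OC)c(OC)c(OC)c4)c3)c(=O)[nH]2)cc1` gives 3500 nM in a functional assay on SN12C cells (Homo sapiens) for inhibition; a lower number here means a stronger inhibitor of growth, a higher number a weaker inhibitor of growth. Compound 1 `COc1cc(/C=C/C(=O)c2cccc(-n3cc(-c4ccc(Cl)cc4)[nH]c3=O)c2)cc(OC)c1OC` gives 5140 nM in this assay; the change from compound 3 is chloro in place of methoxy on an aromatic carbon, and it made the step of a 1.5-fold higher number from compound 3 to compound 1 (0.17 log units; within the scatter). Compound 2 `COc1ccc(-c2cn(-c3cccc(C(=O)/C=C/c4ccc(O)c(OC)c4)c3)c(=O)[nH]2)cc1` gives 4110 nM in this assay; its core differs from that of compound 3 by 4-hydroxy-3-methoxyphenyl in place of 3,4,5-trimethoxyphenyl on a double-bonded chain carbon bound to a double-bonded chain carbon, with the step of a 1.2-fold lower number from compound 2 to compound 3 (0.07 log units; within the scatter). Compound 4 `COc1cc(/C=C/C(=O)c2cccc(-n3cc(-c4ccc(Cl)cc4)[nH]c3=O)c2)ccc1O` is not yet measured in this assay. It differs from compound 2 by chloro in place of methoxy on an aromatic carbon, the same change, at the same place, as from compound 3 to compound 1. The step from compound 2 to compound 4 in this assay is therefore expected to be a 1.5-fold higher number from compound 2 to compound 4 (0.16 log units; within the scatter), beside a 1.5-fold higher number from compound 3 to compound 1 (0.17 log units; within the scatter), resting on that single earlier pair and so on one observation only. Compound 4 is expected to give 6000 nM in this assay, most likely between 3000 nM and 12000 nM.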

Compound 4, concentration for 50% growth inhibition: 2870 nM
Beside the measured number, compound 4's estimate is 2.1-fold (0.32 log units) above it; measured number below the stated range.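

In this assay chloro in place of methoxy gives a 1.4-fold lower number from compound 2 to compound 4 (0.16 log units; within the scatter) on the core of compound 2. Read with the earlier pair, the change does not separate the two cores: the same change on two cores in this assay, a 1.5-fold higher number (0.17 log units; within the scatter) from compound 3 to compound 1 and a 1.4-fold lower number (0.16 log units; within the scatter) from compound 2 to compound 4, 2.1-fold (0.32 log units) apart, within the scatter of two such steps

The 4-methoxyphenyl to 4-chlorophenyl change therefore carries across these two cores with no readable effect on growth inhibition, but two pairs within the scatter give it no reliable size or direction and do not show that it would be neutral on a third core.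

Open, as far as these compounds go, is whether an amine or a carboxylic acid on that aromatic carbon would give a step beyond the scatter. Also open, from the compounds shown here alone, is whether a longer chain there would do so.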